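A few compounds are considered here, and "the series" means these few. Any claim that something is new, unique, unknown or untested is made for them only; others in the source may bear on it.

Three esters built on one shared core have been measured in a functional assay on HepG2 cells (Homo sapiens) for inhibition, read by MTT assay, with a stated time of 72 h; on this read-out lower numbers stand for stronger inhibition and higher numbers for weaker inhibition. Compound 1 `O=C(OC1(C(=O)Nc2ccc([N+](=O)[O-])cc2)CCCCC1)c1ccc(C(F)(F)F)cc1` gives 29.1 nM. Compound 2 `COc1ccc(C(=O)OC2(C(=O)Nc3ccc([N+](=O)[O-])cc3)CCCCC2)cc1` gives 57.1 nM, the second highest of the three numbers; the step from compound 1 to compound 2 is a 2.0-fold higher number from compound 1 to compound 2 (0.29 log units; within the scatter). Compound 3 `CCOC(=O)c1ccccc1C(=O)OC1(C(=O)Nc2ccc([N+](=O)[O-])cc2)CCCCC1` gives 517 nM, a number that lies beyond the scatter above that of compound 2. Compound 4 `O=C(/C=C/c1ccccc1)OC1(C(=O)Nc2ccc([N+](=O)[O-])cc2)CCCCC1` has not yet been measured. It differs from compound 2 by 2-phenylethenyl in place of 4-methoxyphenyl on a carbonyl carbon. Within the data shown here, the only measured step that changes the group on the carbonyl carbon is the one from compound 1 to compound 2, which only exchanged one substituent on the aromatic ring, and it stayed within the scatter. Among the measured compounds shown here, no measured step replaces the whole aromatic group with a 2-phenylethenyl group, so nothing points to a shift in either direction. The step expected in this assay from compound 2 to compound 4 is therefore a 1.1-fold higher number from compound 2 to compound 4 (0.02 log units; within the scatter), none beyond the scatter. Compound 4 is expected to give about 60 nM, with a likely range from 20 nM to 200 nM.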

Compound 4, half-maximal inhibitory concentration: 52.9 nM
Compound 4: middle estimate off by 1.1-fold (0.05 log units), on the high side; measured number inside the range.
By their numbers in this assay, from the lowest: compounds 1, 4 and 2 (each within the scatter of the next); then compound 3.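

In this assay the whole group on the carbonyl carbon is now exchanged, not just one substituent on its aromatic ring: replacing 4-methoxyphenyl with 2-phenylethenyl gives a 1.1-fold lower number from compound 2 to compound 4 (0.03 log units; within the scatter) and replacing 4-(trifluoromethyl)phenyl with it gives a 1.8-fold higher number from compound 1 to compound 4 (0.26 log units; within the scatter). The entering group carries a double bond outside aromatic rings and no hydrogen-bond acceptor, yet neither step leaves the scatter, so at this position these three groups cannot be told apart. No measurement at hand explains why their numbers lie so close.

Open, from the compounds shown here alone, is whether a group with no aromatic ring, such as a plain butyl chain, or one carrying an amine or a carboxylic acid, would keep the number in this range. Open too is what the double bond contributes, as the saturated 2-phenylethyl group is not among these compounds.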